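The compounds below may be only part of what the source reports. "The series", "measured", "known", "first", "only" and "open" are said of these compounds alone.

Working notes on the series.

Compound 1 `COc1cc2c(Oc3ccc(NC(=O)/C=C/S(=O)(=O)c4ccccc4OC)cc3F)ccnc2cc1OCCCN1CCCCC1` is the reference point. Among the measured compounds shown here, in a functional assay on A549 cells (Homo sapiens) for cytotoxicity, read by MTT assay, with a stated time of 72 h (on this read-out higher numbers stand for weaker inhibition and lower numbers for stronger inhibition), compound 1 gives 470 nM, the lowest of the two numbers measured so far. For the measured compounds named here, its only measured neighbour is compound 2 `COc1ccc(S(=O)(=O)/C=C/C(=O)Nc2ccc(Oc3ccnc4cc(OCCCN5CCCCC5)c(OC)cc34)c(F)c2)cc1`, which in this assay gives 2220 nM; the one step known, a 4.7-fold higher number from compound 1 to compound 2 (0.67 log units; beyond the scatter), is a change on the sulfonyl-bearing aryl group at the far end of the molecule.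

Compound 3 `COc1cc2c(Oc3ccc(NC(=O)/C=C/S(=O)(=O)c4ccccc4OC)cc3F)ccnc2cc1OCCCN1CCC(C)CC1` has not yet been measured. It differs from compound 1 in a single place: methyl in place of hydrogen on a saturated ring carbon. The change sits on the saturated ring at the basic end of the propoxy chain, well away from the sulfonyl aryl group altered between compound 1 and compound 2. Going by the values given here, no measured step touches the piperidine ring, so the one known step gives no direct guide, and a small group such as a single methyl on a saturated ring carbon is not expected to shift the number in this assay beyond the scatter in either direction.

Compound 3 is therefore estimated at 520 nM in this assay, with a range of 200 nM to 1400 nM; the expected step of a 1.1-fold higher number from compound 1 to compound 3 (0.04 log units; within the scatter) is within the scatter.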

Compound 3, half-maximal inhibitory concentration: 3000 nM
Beside the measured number, compound 3's estimate is 5.8-fold (0.76 log units) below it; measured number above the stated range.
By their numbers in this assay, from the lowest: compound 1; then compounds 2 and 3 (each within the scatter of the next).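

The piperidine ring at the end of the propoxy chain is not a silent part of compound 1: in this assay, the change to 4-methylpiperidin-1-yl gives a 6.4-fold higher number from compound 1 to compound 3 (0.81 log units; beyond the scatter), so one added methyl on a saturated ring carbon, three ring bonds from the ring nitrogen, is enough to move the number beyond the scatter. Taken with a 4.7-fold higher number from compound 1 to compound 2 (0.67 log units; beyond the scatter), both measured changes from compound 1, one on the sulfonyl aryl group and one on the piperidine ring, give higher numbers, and neither has yet given a lower one. Nothing measured here accounts for the rise seen with the methyl.

The compounds shown leave open whether this higher number belongs to the methyl alone or to any group on this ring carbon, which a hydroxyl or an ethyl at the same place would help to settle. They also leave open how much the piperidine ring itself counts, for which a morpholine or a dimethylamine on the same propoxy chain would be the direct comparison.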